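Replacing the Amide Partner: From Compound 3 to Compound 4

The compounds below may be only part of what the source reports. "The series", "measured", "known", "first", "only" and "open" are said of these compounds alone.

Compound 1 `CCN(CC)S(=O)(=O)c1ccc(S(=O)(=O)N2CCC[C@@H](C(=O)N3CCC(OC)CC3)C2)cc1`: 50 nM
Compound 2 `CCN(CC)S(=O)(=O)c1ccc(S(=O)(=O)N2CCC[C@@H](C(=O)N3CCOCC3)C2)cc1`: 160 nM
Compound 3 `CCN(CC)S(=O)(=O)c1ccc(S(=O)(=O)N2CCC[C@@H](C(=O)N[C@H]3CCOC3)C2)cc1`: 290 nM

All three were tested in a functional assay on MIA PaCa-2 cells (Homo sapiens) for inhibition, read by MTT assay, with a stated time of 3 days; a higher number here means a weaker inhibitor, a lower number a stronger inhibitor. Compound 3 gives the highest number of the three: its difference from compound 2 is a 1.8-fold higher number from compound 2 to compound 3 (0.26 log units; within the scatter), whereas the step of a 5.8-fold higher number from compound 1 to compound 3 (0.76 log units; beyond the scatter) lies beyond the scatter. Compound 4 `CCN(CC)S(=O)(=O)c1ccc(S(=O)(=O)N2CCC[C@@H](C(=O)N3CCC(C(F)(F)F)CC3)C2)cc1` differs from compound 3 by 4-(trifluoromethyl)piperidin-1-yl in place of (oxolan-3-yl)amino on a carbonyl carbon. Among the measured compounds shown here, no measured step makes exactly this swap; the nearest guide is compound 1, which also carries a six-membered piperidine on the carbonyl carbon, and the steps of a 3.2-fold higher number from compound 1 to compound 2 (0.51 log units; beyond the scatter) and a 5.8-fold higher number from compound 1 to compound 3 (0.76 log units; beyond the scatter) show that changes at this position shift the number modestly. Relative to compound 3, compound 4 is therefore expected to shift by a 3.6-fold lower number from compound 3 to compound 4 (0.56 log units; beyond the scatter). The estimate for compound 4 is 80 nM, within a range from 25 nM to 300 nM.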

Compound 4, half-maximal inhibitory concentration: 110 nM
For compound 4 the middle estimate is 1.4-fold (0.14 log units) below the measured one; the measured number falls inside the stated range.
By their numbers in this assay, from the lowest: compound 1; then compounds 4, 2 and 3 (each within the scatter of the next, the first and the last beyond it).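

In this assay, 4-(trifluoromethyl)piperidin-1-yl in place of (oxolan-3-yl)amino gives a 2.6-fold lower number from compound 3 to compound 4 (0.42 log units; beyond the scatter), while in place of morpholin-4-yl it gives a 1.5-fold lower number from compound 2 to compound 4 (0.16 log units; within the scatter), a change that stays within the scatter. With the piperidine ring kept, the group on its saturated ring carbon still matters: trifluoromethyl in place of methoxy gives a 2.2-fold higher number from compound 1 to compound 4 (0.34 log units; beyond the scatter). Nothing measured here explains these differences. The compounds shown leave open how an unsubstituted piperidine, or a piperidine carrying a hydroxyl group or an amine on that ring carbon, would compare.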